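From Chloro to Bromo: What to Expect for Compound 3

The source may hold more compounds than are shown below. What is called first, only, known or untested is meant among the compounds shown, and "the series" means these compounds.

Of the compounds shown here, two have been measured in a functional assay on B16-F10 cells (Mus musculus) for antiproliferative activity, read by ELISA and MTT assay, with a stated time of 48 h; on this read-out higher numbers stand for weaker inhibition and lower numbers for stronger inhibition. Compound 1, `O=C(/C=C/c1ccc(F)cc1)NS(=O)(=O)c1ccc(Br)cc1`, gives 2.8 ug/mL in this assay. Compound 2, `COc1ccc(/C=C/C(=O)NS(=O)(=O)c2ccc(Cl)cc2)cc1`, gives 5.3 ug/mL in this assay. Among the two numbers shown, that of compound 2 is the larger, but its gap to compound 1 lies within the usual scatter of repeated measurements, so the two cannot be told apart on this evidence.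

Compound 3, `COc1ccc(/C=C/C(=O)NS(=O)(=O)c2ccc(Br)cc2)cc1`, has not yet been measured in this assay. It differs from compound 2 in a single place: bromo in place of chloro on an aromatic carbon. The halogen on that ring is thus exchanged for another, leaving the rest of the molecule unchanged.

Within the data shown here, no step between two measured compounds that differ in one place is available, so the size of this exchange cannot be read from the data. The expected step from compound 2 to compound 3 is a 1.2-fold lower number from compound 2 to compound 3 (0.07 log units; within the scatter), meaning no change beyond the scatter in either direction. Compound 3 is estimated to give 4.5 ug/mL in this assay, with a range from 2.3 ug/mL to 9 ug/mL.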

Compound 3, half-maximal inhibitory concentration: 5.8 ug/mL
Estimate against measurement, compound 3: 1.3-fold (0.11 log units) below; the measured number falls inside the stated range.
By their numbers in this assay, from the lowest: compounds 1, 2 and 3 (each within the scatter of the next, the first and the last beyond it).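

Replacing chloro with bromo on this aromatic carbon, para to a large group, gives a 1.1-fold higher number from compound 2 to compound 3 (0.04 log units; within the scatter) in this assay with the methoxy group held constant, so these two halogens cannot be told apart at this position. Compound 3 also provides a comparison with compound 1, which keeps bromo and changes only one other place, methoxy in place of fluoro, giving a 2.1-fold higher number from compound 1 to compound 3 (0.32 log units; beyond the scatter) and thus a modest step just beyond the scatter. Among these three compounds, then, the halogen exchange leaves no readable mark on the number while the methoxy-for-fluoro exchange does, although each conclusion rests on a single pair. Nothing available here accounts for the size of either step.

The compounds shown leave open how this position responds to groups other than halogens, such as an amine or a carboxylic acid in place of bromo. From the compounds shown here alone, it is equally open whether a longer chain, such as ethoxy in place of methoxy, would extend the modest step seen with methoxy or reverse it.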